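This account rests on a few compounds, and the source may have more. Where it says the series, first, only, none or still open, it means among the compounds named here.

Three measured compounds share one core and differ only in the ring system attached to it and in the ester at the far end. Compound 1 `CCOC(=O)/C=C/c1ccncc1-c1ccc2[nH]ccc2c1` and compound 3 `CCOC(=O)/C=C/c1ccncc1-c1ccc2cc[nH]c2c1` carry closely related ring systems, while compound 2 `COC(=O)/C=C/c1ccncc1-c1ccc2ccccc2c1` carries a different one. All three were tested in a functional assay on A549 cells (Homo sapiens) for inhibition, read by sulforhodamine B assay, with a stated time of 72 h; on this read-out higher numbers stand for weaker inhibition of growth and lower numbers for stronger inhibition of growth. In this assay compound 1 gives 7440 nM, compound 3 gives 5740 nM, and compound 2 gives 760 nM. Compound 2 thus has the lowest number of the three, and both gaps to it lie beyond the usual scatter of repeated measurements, so compound 2 stands as the strongest inhibitor of growth among those measured.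

Compound 4 `CN(C)C(=O)/C=C/c1ccncc1-c1ccc2ccccc2c1` has not yet been measured. It differs from compound 2 in a single place: dimethylamino in place of methoxy on a carbonyl carbon. No two of the measured compounds differ in exactly this way, so nothing measured shows what such a change does here. The expectation therefore rests only on compound 2 and its value 760 nM. A step of moderate size in either direction would not be surprising, and the estimated step is a 2.0-fold higher number from compound 2 to compound 4 (0.30 log units; within the scatter), leaning toward a somewhat higher number. Compound 4 is expected to give 1500 nM in this assay, with a range from 400 nM to 6000 nM.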

Compound 4, concentration for 50% growth inhibition: 5800 nM
Beside the measured number, compound 4's estimate is 3.9-fold (0.59 log units) below it; low and high end bracket the measured number.
By their numbers in this assay, from the lowest: compound 2; then compounds 3, 4 and 1 (each within the scatter of the next).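

Within the data shown here, this gives the first direct reading of the group at the far end of the molecule. In this assay, putting dimethylamino in place of methoxy on the carbonyl carbon, which turns methoxycarbonyl into dimethylcarbamoyl, gives a 7.6-fold higher number from compound 2 to compound 4 (0.88 log units; beyond the scatter). With the ring system held constant, the group on this carbonyl carbon therefore clearly affects growth inhibition, and the ester is the stronger inhibitor of this pair, something no earlier pair could show; no measurement at hand accounts for the size of this step.

Still open, on these data alone, is how much of the step belongs to nitrogen replacing oxygen and how much to the two methyl groups, a question that the unsubstituted amide, the monomethyl amide or the free carboxylic acid on the same scaffold could help to settle. As far as these compounds go, it is also open whether the same change would have a similar effect on the ring systems of compound 1 and compound 3, where the ester is an ethyl ester rather than a methyl ester.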